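The source may hold more compounds than are shown below. What is called first, only, known or untested is meant among the compounds shown, and "the series" means these compounds.

Three compounds that share an N-hydroxyacetamide group on a carbon attached to an aromatic ring have been measured in an assay on RBL-1 cells for inhibition of Polyunsaturated fatty acid 5-lipoxygenase (Rattus norvegicus); on this read-out lower numbers stand for stronger inhibition and higher numbers for weaker inhibition. Compound 1, `CC(=O)N(O)C(C)c1ccc(OCc2ccccc2)cc1`, gives 280 nM in this assay. Compound 2, `CCCCOc1ccc(C(CC)N(O)C(C)=O)cc1`, gives 740 nM, and compound 3, `CCCCOc1ccc(C(C(C)C)N(O)C(C)=O)cc1`, gives 880 nM. Compound 2 and compound 3 differ in one place only, (methyl in place of hydrogen on a saturated chain carbon bound to two saturated chain carbons), and that change produced a 1.2-fold higher number from compound 2 to compound 3 (0.08 log units; within the scatter). Compound 1 and compound 2 differ in more than one place, and the difference between the two cores is not broken down here; what can be said is that compound 1 gives the lowest of the three numbers, with compound 2 and compound 3 both beyond the scatter of it.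

Compound 4, `CC(=O)N(O)C(C)c1ccc(OC(C)c2ccccc2)cc1`, has not yet been measured. It differs from compound 1 by methyl in place of hydrogen on a saturated chain carbon bound to an aromatic carbon and an oxygen on an aromatic ring. For the measured compounds named here, this is the same kind of change as the one from compound 2 to compound 3, but the place is not the same: there the carbon carrying the new methyl was bound to two saturated chain carbons, whereas here it is bound to an aromatic carbon and an oxygen on an aromatic ring. Because the earlier step was only a 1.2-fold higher number from compound 2 to compound 3 (0.08 log units; within the scatter), a similarly small step, a 1.3-fold higher number from compound 1 to compound 4 (0.11 log units; within the scatter), is expected from compound 1 to compound 4 in this assay, with some extra uncertainty since the surroundings of the change differ. Compound 4 is therefore estimated at 360 nM, most likely between 150 nM and 850 nM.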

Compound 4, half-maximal inhibitory concentration: 500 nM
Beside the measured number, compound 4's estimate is 1.4-fold (0.14 log units) below it, and the stated range covers the measured number.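

In this assay, a methyl in place of hydrogen on a saturated chain carbon bound to an aromatic carbon and an oxygen on an aromatic ring gave a 1.8-fold higher number from compound 1 to compound 4 (0.25 log units; within the scatter). Set beside the earlier case, where the methyl went onto a saturated chain carbon bound to two saturated chain carbons, the new step does not stand apart from it, so the two cores give no sign of treating this change differently: the same change on two cores in this assay, a 1.2-fold higher number (0.08 log units; within the scatter) from compound 2 to compound 3 and a 1.8-fold higher number (0.25 log units; within the scatter) from compound 1 to compound 4, 1.5-fold (0.18 log units) apart, within the scatter of two such steps

This shows that, for these two pairs of compounds, the added methyl left the number within the scatter on both cores, but it does not establish a rule, since two pairs are little to go on, the carbon carrying the methyl is not the same kind in each, and steps this small could hide a real difference between the cores.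

The compounds shown leave open what a longer chain, an amine or a carboxylic acid in place of the methyl would do on either core. They also leave open whether the step would stay this small on a third core.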